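The source may hold more compounds than are shown below. What is called first, only, known or untested is meant among the compounds shown, and "the series" means these compounds.

Compound 2 `COC(CNc1ccccc1CO)n1cc(F)c(=O)[nH]c1=O` gives 36000 nM in a functional assay on MCF7 cells (Homo sapiens) for antiproliferative activity (a higher number here means a weaker inhibitor, a lower number a stronger inhibitor), the lowest of the two numbers recorded, with compound 3 nearest. Compound 3 `COC(CN(c1ccccc1CO)S(=O)(=O)c1ccccc1[N+](=O)[O-])n1cc(F)c(=O)[nH]c1=O` gives 91000 nM in this assay. Compound 1 `COC(CN(c1ccccc1CO)S(=O)(=O)c1ccccc1N)n1cc(F)c(=O)[nH]c1=O` reaches only a limit of the assay, > 100000 nM, and not a number. Compound 4 `COC(CN(C(=O)c1ccccc1)c1ccccc1CO)n1cc(F)c(=O)[nH]c1=O` has not yet been measured; it differs from compound 2 by benzoyl in place of hydrogen on a nitrogen on an aromatic ring.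

Among the measured compounds shown here, two measured steps bear on this change. The step of an at least 2.7-fold lower number from compound 1 to compound 2 (0.44 log units; beyond the scatter) shows that stripping a large sulfonyl substituent from this nitrogen lowers the number, with compound 1 at the limit (the limit of > 100000 nM in this assay, at which 1 of the 3 values shown sits). The step of an at least 1.0-fold lower number from compound 1 to compound 3 (0.04 log units; that floor lies within the scatter) shows a swap within the substituent that stays within the scatter. Putting a benzoyl group back on the same nitrogen is therefore expected to move the number in the opposite direction to the first step, so a higher number is expected for compound 4, a step of a 2.2-fold higher number from compound 2 to compound 4 (0.35 log units; beyond the scatter). Compound 4 is estimated at 80000 nM, within 30000 nM to 200000 nM.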

Compound 4, half-maximal inhibitory concentration: 16100 nM
The estimate for compound 4 lay 5.0-fold (0.70 log units) above the measured number, and the stated range ends above it.
By their numbers in this assay, from the lowest: compound 4; then compound 2; then compound 3. At a limit, above all of these: compound 1.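

In this assay, putting a group on this nitrogen does not by itself raise the number: benzoyl in place of hydrogen gives a 2.2-fold lower number from compound 2 to compound 4 (0.35 log units; beyond the scatter), the opposite direction to the earlier step from a sulfonyl group to hydrogen, an at least 2.7-fold lower number from compound 1 to compound 2 (0.44 log units; beyond the scatter). What matters is therefore which group sits there, and benzoyl in place of (2-aminophenyl)sulfonyl gives an at least 6.2-fold lower number from compound 1 to compound 4 (0.79 log units; beyond the scatter). That step starts from compound 1, whose value is a limit and not a number: the limit of > 100000 nM in this assay, at which 1 of the 4 values shown sits.

Going by these compounds, whether the change follows the carbonyl or the aromatic ring of benzoyl remains open, and an acetyl or a benzyl group on this nitrogen would separate the two. Also open, on these data alone, is how a nitro or an amino group on the benzoyl ring would shift the number.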